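The compounds below may be only part of what the source reports. "The series", "measured", "known", "first", "only" and "open" are said of these compounds alone.

The measured compounds in a functional assay on MIA PaCa-2 cells (Homo sapiens) for inhibition, read by MTT assay, with a stated time of 3 days (a higher number here means a weaker inhibitor, a lower number a stronger inhibitor), are:

- compound 1, `CCN(CC)S(=O)(=O)c1ccc(S(=O)(=O)N2CCC[C@@H](C(=O)NC3CN(C(=O)C4CC4)C3)C2)cc1`: 3100 nM
- compound 2, `CCN(CC)C(=O)[C@@H]1CCCN(S(=O)(=O)c2ccc(S(=O)(=O)N(CC)CC)cc2)C1`: 700 nM
- compound 3, `CCN(CC)S(=O)(=O)c1ccc(S(=O)(=O)N2CCC[C@@H](C(=O)N3CCN(c4nc(C)no4)CC3)C2)cc1`: 200 nM

Compound 2 stands second highest of the three numbers. Its nearest neighbour is compound 3, reached by a 3.5-fold lower number from compound 2 to compound 3 (0.54 log units; beyond the scatter); its furthest is compound 1, from which compound 2 is reached by a 4.4-fold lower number from compound 1 to compound 2 (0.65 log units; beyond the scatter). All three measured compounds share the same core and differ only in what sits on the carbonyl carbon.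

Compound 4, `CCN(CC)S(=O)(=O)c1ccc(S(=O)(=O)N2CCC[C@@H](c3nc(C)no3)C2)cc1`, is not yet measured. It differs from compound 2 by 3-methyl-1,2,4-oxadiazol-5-yl in place of diethylcarbamoyl on a saturated ring carbon. Among the measured compounds shown here, this change removes the carbonyl group altogether, so none of the measured steps is a direct match. The step from compound 2 to compound 3 shows that the oxadiazole, carried on a piperazine amide, goes with a lower number, but in compound 4 it stands directly on the saturated ring carbon with nothing of the amide left. The measured steps therefore only loosely bear on this change, and the direction is open.

Compound 4 is expected to give about 1000 nM in this assay, with a range from 300 nM to 4000 nM. That estimate means a step of a 1.4-fold higher number from compound 2 to compound 4 (0.15 log units; within the scatter), within or close to the scatter, with wide uncertainty.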

Compound 4, half-maximal inhibitory concentration: 700 nM
Compound 4: middle estimate off by 1.4-fold (0.15 log units), on the high side; the range from low to high includes it.
By their numbers in this assay, from the lowest: compound 3; then compounds 2 and 4 (each within the scatter of the next); then compound 1.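

In this assay, putting 3-methyl-1,2,4-oxadiazol-5-yl in place of diethylcarbamoyl on the saturated ring carbon gives no change at the digits printed from compound 2 to compound 4 (within the scatter) and so shows that this position tolerates the loss of the carbonyl. Among the compounds shown here, all the earlier compounds kept a carbonyl on this ring carbon and varied only the amine part attached to it, so they could not show whether a group without a carbonyl would read at a similar level. The result also shows that a five-membered aromatic ring with 3 hetero atoms, standing directly on the ring carbon, can take the place of an open diethylcarbamoyl group with no ring, at least in this one pair.

The compounds shown leave open how a carboxylic acid, a primary amine or a plain methyl on this ring carbon would read, and whether the methyl on the oxadiazole matters, which a cyclopropyl or a phenyl in its place would test. On these data alone, it also remains open whether other directly attached five-membered aromatic rings, such as a 1,3,4-oxadiazole or a 1,2,3-triazole, would read like compound 4 in this assay and whether any could reach the level of compound 3. Nothing available here explains why the two groups read alike.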